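The source may report more compounds than this note shows. Statements on the series, on what has been measured and on what is new or still open speak of the compounds shown alone.

Working notes on the series.

The shared core is that of compound 1 `N#Cc1cccc([C@]23CCC(N(CCN4CC[C@@H](O)C4)C(=O)Nc4cccc(Br)c4)CC2C3)c1`, compound 2 `CC(C)N(CCN(C(=O)Nc1ccc(F)c(Cl)c1)C1CC[C@]2(c3cccc(C#N)c3)CC2C1)C(C)C` and compound 3 `CC(C)N(CCN(C(=O)Nc1cccc([N+](=O)[O-])c1)C1CC[C@]2(c3cccc(C#N)c3)CC2C1)C(C)C`; compound 4 `CC(C)N(CCN(C(=O)Nc1cccc(Br)c1)C1CC[C@]2(c3cccc(C#N)c3)CC2C1)C(C)C` is the unmeasured member. In a functional assay for antagonist activity at melanin-concentrating hormone receptor 1 (Homo sapiens) (a higher number here means a weaker inhibitor, a lower number a stronger inhibitor), compound 1 gives 34 nM, compound 2 gives 4.98 nM, and compound 3 gives 2.7 nM. Within the data shown here, compound 3 thus holds the lowest of the three numbers so far, with compound 2 nearest and compound 1 furthest.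

Among the measured compounds shown here, the one single-point step available is a 1.8-fold lower number from compound 2 to compound 3 (0.27 log units; within the scatter), which exchanges one substituted phenyl on the amide-type nitrogen for another and stays within the scatter. Compound 1 carries the same bromophenyl urea as compound 4 but differs from compound 3 in two places, so its value can only be noted beside the others, not read as a step.

The change at hand is bromo in place of nitro on an aromatic carbon. For the measured compounds named here, the only step that bears on it, from compound 2 to compound 3, is small, and it touches the same ring; no step shows the bromo against the nitro directly. On that basis no change beyond the scatter is expected in this assay, the expected step being a 1.5-fold higher number from compound 3 to compound 4 (0.17 log units; within the scatter). Compound 4 is therefore estimated at 4 nM, with a range from 1.5 nM to 12 nM.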

Compound 4, inhibition constant: 5.7 nM
The estimate for compound 4 lay 1.4-fold (0.15 log units) below the measured number; the range from low to high includes it.
By their numbers in this assay, from the lowest: compounds 3, 2 and 4 (each within the scatter of the next, the first and the last beyond it); then compound 1.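

In this assay, among these compounds, the earlier compounds offered no direct comparison of bromo with nitro on this aromatic carbon; the new pair gives a 2.1-fold higher number from compound 3 to compound 4 (0.32 log units; beyond the scatter) and so shows a modest difference between these two groups at this place. The comparison with the 3-chloro-4-fluorophenyl group gives a 1.1-fold higher number from compound 2 to compound 4 (0.06 log units; within the scatter) and so does not separate 3-bromophenyl from that group in this assay. Among the compounds shown here, compound 4 also provides the first reading of the amine end that differs in one place only: diisopropylamino in place of 3-hydroxypyrrolidin-1-yl gives a 6.0-fold lower number from compound 1 to compound 4 (0.78 log units; beyond the scatter) and is a modest change at the saturated chain carbon.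

Still open, on these data alone, is how other groups on this aromatic carbon, such as methoxy or an amino group, would read against bromo and nitro. Also open, as far as these compounds go, is whether the bromo and nitro difference carries over to other amine ends, such as morpholine or dimethylamino, including the 3-hydroxypyrrolidin-1-yl end of compound 1. No supporting measurement is available to explain the size of any of these steps.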